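A few compounds are considered here, and "the series" means these few. Any claim that something is new, unique, unknown or untested is made for them only; others in the source may bear on it.

Measured so far in a functional assay on HCT-116 cells (Homo sapiens) for antiproliferative activity, read by MTT assay, with a stated time of 48 h; on this read-out lower numbers stand for stronger inhibition and higher numbers for weaker inhibition:
Compound 1 `N#CC1=C(N)Oc2c(c3nc4ccccc4nc3c3ccccc23)C12C(=O)N(Cc1cnnn1-c1ccccc1Cl)c1ccccc12`: compound 1 gives > 50000 nM, which is a limit of the assay and not a number.
Compound 2 `N#CC1=C(N)Oc2c(c3nc4ccccc4nc3c3ccccc23)C12C(=O)N(Cc1cnnn1-c1cccc(S(N)(=O)=O)c1)c1ccccc12`: compound 2 gives 11300 nM.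
Compound 3 `N#CC1=C(N)Oc2c(c3nc4ccccc4nc3c3ccccc23)C12C(=O)N(Cc1cnnn1-c1ccc(F)c(Cl)c1)c1ccccc12`: compound 3 gives > 50000 nM, again a limit of the assay.

Compound 3 thus stands at the limit, with no number of its own; (the limit of > 50000 nM in this assay, at which 2 of the 3 values shown sit). Compound 4 `N#CC1=C(N)Oc2c(c3nc4ccccc4nc3c3ccccc23)C12C(=O)N(Cc1cnnn1-c1cc(Cl)ccc1Cl)c1ccccc12` differs from compound 3 in one place: 2,5-dichlorophenyl in place of 3-chloro-4-fluorophenyl on an aromatic nitrogen.

For the measured compounds named here, two measured steps touch compound 3. The step that the two limits leave unreadable from compound 1 to compound 3 cannot be read, since both ends sit at the limit. The step of an at least 4.4-fold higher number from compound 2 to compound 3 (0.64 log units; beyond the scatter) shows that the 3-chloro-4-fluorophenyl group falls outside the window that the 3-sulfamoylphenyl group reaches; the step of an at least 4.4-fold lower number from compound 1 to compound 2 (0.64 log units; beyond the scatter) shows the same for the 2-chlorophenyl group. Compound 4 keeps a halogen-only phenyl of the kind carried by compound 1 and compound 3, and nothing in the shown values separates one such phenyl from another. The step expected in this assay is therefore a step that the limit leaves unreadable from compound 3 to compound 4, none beyond the scatter. Compound 4 is estimated at 60000 nM, between 20000 nM and 200000 nM, and is most likely reported again only as a limit.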

Compound 4, half-maximal inhibitory concentration: > 50000 nM
Compound 4 was reported as a limit; the forecaster's own chance of this, stated with the estimate: 75%; the middle value does not contradict the limit.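

In this assay compound 4 gives > 50000 nM, which is a limit of the assay and not a number. On the aromatic nitrogen, the 2,5-dichlorophenyl group now joins the 2-chlorophenyl and 3-chloro-4-fluorophenyl groups at this limit, and the step of an at least 4.4-fold higher number from compound 2 to compound 4 (0.64 log units; beyond the scatter) sets it apart from the 3-sulfamoylphenyl group, while the steps among the three halogen-only phenyl compounds cannot be read, since both ends of each sit at the limit. A second chlorine on the phenyl of compound 1 therefore brings no readable value, and among the halogen-only phenyl groups shown, neither a second chlorine nor a chlorine with a fluorine gives a number, leaving compound 2 as the only compound with one: the limit of > 50000 nM in this assay, at which 3 of the 4 values shown sit.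

What lies behind the three limits stays open, so no order among the halogen-only phenyl compounds can be given. On these data alone, it is also open whether the readable value belongs to the 3-sulfamoylphenyl group alone, or whether a phenyl carrying a carboxylic acid or an amine would also give a number in this assay.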